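Thioether side chain variation on a bicyclic prostanoid core

A few compounds are considered here, and "the series" means these few. Any claim that something is new, unique, unknown or untested is made for them only; others in the source may bear on it.

Measured in a functional assay on a cell-free system (plasma) for inhibition of thromboxane A2 receptor (Homo sapiens); a higher number here means a weaker inhibitor, a lower number a stronger inhibitor:
compound 1 `CCCCCCSC[C@H]1C2CC[C@@H](O2)[C@H]1C/C=C\CCCC(=O)O` — 115000 nM; > 1000000 nM; > 1000000 nM (3 entries)
compound 2 `CCCCSCSCC1C2CCC(O2)C1C/C=C\CCCC(=O)O` — 700 nM

Compound 2 stands as the only number shown for this series beside one further entry that gives no single number. Going by the values given here, for compound 1 the repeated entries the several entries of compound 1 in this assay, 115000 nM; > 1000000 nM; > 1000000 nM (3 entries) span one number and limits of the assay, so no step between compound 1 and compound 2 is computed; their values show only that the two differ widely.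

Compound 3 `CCC/C=C(\C)CSCC1C2CCC(O2)C1C/C=C\CCCC(=O)O` is not yet measured. Relative to compound 2 the change is a group of 6 heavy atoms (6 carbon; no ring) in place of a group of 5 heavy atoms (4 carbon, 1 sulfur; no ring), on a saturated chain carbon bound to a sulfur; in words, a group of 6 heavy atoms (6 carbon; no ring) in place of a group of 5 heavy atoms (4 carbon, 1 sulfur; no ring), on a saturated chain carbon bound to a sulfur. Among the compounds with values here, with no measured step of this kind, the expectation rests on compound 1, whose single-thioether side chain gave (the several entries of compound 1 in this assay, 115000 nM; > 1000000 nM; > 1000000 nM (3 entries)). For compound 3 a weakening step is expected, a 29-fold higher number from compound 2 to compound 3 (1.46 log units; beyond the scatter), well beyond the scatter. Compound 3 is thus estimated at 20000 nM, in the range 2000 nM to 200000 nM.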

Compound 3, half-maximal inhibitory concentration: 1100 nM
Compound 3: the middle estimate sits 18-fold (1.26 log units) above what was measured, and the stated range ends above it.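

In this assay, putting the all-carbon group of 6 carbon atoms, with its 1 double bond outside aromatic rings, in place of butylsulfanyl on a saturated chain carbon bound to a sulfur gives a 1.6-fold higher number from compound 2 to compound 3 (0.20 log units; within the scatter). Compound 2 and compound 3 therefore cannot be told apart here, so at this place the sulfur of the butylsulfanyl group and its 1 hydrogen-bond acceptor are not needed to keep a value of this size, at least for this one replacement. Compound 1 gives no readable step to either compound, since its entries mix a single number with limits of the assay: the several entries of compound 1 in this assay, 115000 nM; > 1000000 nM; > 1000000 nM (3 entries)

Going by these compounds alone, what the double bond in compound 3 contributes on its own remains open, as no pair here differs in that feature alone. Also open, from the compounds shown here alone, is whether the value holds when a phenyl ring, an amine or a longer chain sits at this place, so the two compounds with single numbers mark out only a narrow part of what this position accepts.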